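A few compounds are considered here, and "the series" means these few. Any claim that something is new, unique, unknown or untested is made for them only; others in the source may bear on it.

In a functional assay on HL-60 cells (Homo sapiens) for cytotoxicity, read by MTT assay (a higher number here means a weaker inhibitor, a lower number a stronger inhibitor), compound 1 `N=c1c2cnn(-c3ccccc3)c2ncn1-c1ccc(-c2ccc(F)cc2)s1` gives 1010 nM, and compound 2 `N=c1c2cnn(-c3ccccc3)c2ncn1-c1ccc(-c2ccccc2F)s1` gives 900 nM. These two numbers lie within the scatter of each other, so compound 2 stands level with compound 1 and neither can be ranked ahead of the other.

The next compound, compound 3 `N=c1c2cnn(-c3ccccc3)c2ncn1-c1ccc(-c2ccc(C(F)(F)F)cc2)s1`, keeps the shared core but carries 4-(trifluoromethyl)phenyl in place of 2-fluorophenyl on an aromatic carbon. The swap sits on an aromatic carbon of a five-membered aromatic ring with 1 sulfur, next to the ring sulfur.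

Among the measured compounds shown here, one measured step bears on this change, a swap of aryl groups at the same place, with 2-fluorophenyl in place of 4-fluorophenyl: a 1.1-fold lower number from compound 1 to compound 2 (0.05 log units; within the scatter). That step stays within the scatter, so it gives no sign that this place responds strongly to such swaps. However, no compound with a trifluoromethyl group has been measured yet, which leaves the evidence thin.

The expected result is therefore no clear shift in either direction, and the estimated step is no change at the digits printed from compound 2 to compound 3 (within the scatter). For compound 3 the estimated value is 900 nM, with an expected range from 400 nM to 2000 nM.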

Compound 3, half-maximal inhibitory concentration: 210 nM
Compound 3: the middle estimate sits 4.3-fold (0.63 log units) above what was measured, and the stated range ends above it.
By their numbers in this assay, from the lowest: compound 3; then compounds 2 and 1 (each within the scatter of the next).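

In this assay this place, on an aromatic carbon of a five-membered aromatic ring with 1 sulfur, now proves able to respond to the group it carries: swapping 2-fluorophenyl for 4-(trifluoromethyl)phenyl gives a step beyond the scatter (a 4.3-fold lower number from compound 2 to compound 3 (0.63 log units; beyond the scatter)), whereas the earlier swap between the two fluorophenyl groups stayed within it. Among the compounds shown here, the single change of trifluoromethyl in place of fluoro on the phenyl ring gives a step of similar size (a 4.8-fold lower number from compound 1 to compound 3 (0.68 log units; beyond the scatter)), so the lower number holds against both fluorinated compounds, and the two fluorophenyl compounds remain level with each other. Nothing measured here explains why the number falls with this group.

For the compounds shown here, only one compound carries trifluoromethyl, so it remains open whether the lower number belongs to that group specifically or would also appear with another group on the phenyl ring, such as a chlorine, a methoxy group or a nitrile. Also open, from the compounds shown here alone, is how a phenyl ring with no added group at all would compare with these three compounds, and whether 2-(trifluoromethyl)phenyl would match 4-(trifluoromethyl)phenyl.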